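This account rests on a few compounds, and the source may have more. Where it says the series, first, only, none or still open, it means among the compounds named here.

Working notes on the series. Compound 1 `CCn1c(-c2ccccc2)nc2c(NC3CCCCC3)ncnc21` gives 10 nM in an assay on CHO cells for displacement of a labelled ligand from adenosine receptor A1 (Homo sapiens), read by scintillation counting, with a stated time of 3 h; a lower number here means a stronger inhibitor, a higher number a weaker inhibitor; compound 2 `CCn1c(-c2ccccc2)nc2c(NC3CCC3)ncnc21` gives 6 nM. Compound 1 thus holds the higher of the two numbers, and the step of a 1.7-fold lower number from compound 1 to compound 2 (0.22 log units; within the scatter) stays within the scatter. Compound 3 `CCCn1c(-c2ccccc2)nc2c(NC3CCCCC3)ncnc21` differs from compound 1 by methyl in place of hydrogen on a saturated chain carbon, two bonds along the chain from an aromatic nitrogen. Among the measured compounds shown here, the only measured step concerns the ring on the nitrogen, not this chain, so no measured step bears on it and nothing beyond the scatter is expected. Compound 3 is therefore expected near 10 nM, in the range 4 nM to 25 nM. The expected step of no change at the digits printed from compound 1 to compound 3 (within the scatter) is small.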

Compound 3, inhibition constant: 27 nM
Beside the measured number, compound 3's estimate is 2.7-fold (0.43 log units) below it; the measured number lies above the stated range.
By their numbers in this assay, from the lowest: compounds 2 and 1 (each within the scatter of the next); then compound 3.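

In this assay, among the compounds shown here, the change from ethyl to propyl gives a 2.7-fold higher number from compound 1 to compound 3 (0.43 log units; beyond the scatter) and is the first step beyond the scatter. The chain on the aromatic nitrogen is therefore not indifferent: one added methyl at this carbon registers, though modestly, whereas the cyclobutyl for cyclohexyl step stayed within the scatter. No measurement at hand accounts for this step. From the compounds shown here alone, whether the number keeps rising with a longer chain such as butyl remains open. So does whether a chain ending in a hydroxyl group or an amine follows the same direction.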